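Swapping a para bromo for an ortho fluoro on the phenyl ring

The source may report more compounds than this note shows. Statements on the series, on what has been measured and on what is new or still open speak of the compounds shown alone.

Two compounds share one core and differ only in the ring hanging from it. Compound 1 `c1ccc(-c2cn3ccnc3c(-c3ccc4ncn(C5CCCCC5)c4c3)n2)cc1` carries a plain phenyl; in a functional assay on K562 cells (Homo sapiens) for inhibition, read by sulforhodamine B assay, with a stated time of 48 h, tested at 10 uM (a lower number here means less inhibition, a higher number more inhibition at the concentration tested (going by the name of the read-out)), compound 1 gives 70.6%. Compound 2 `Brc1ccc(-c2cn3ccnc3c(-c3ccc4ncn(C5CCCCC5)c4c3)n2)cc1` carries a 4-bromophenyl instead, and in this assay compound 2 gives 59%, the lower of the two numbers measured. Among the measured compounds shown here, the only step measured so far is a number 11.6 percentage points lower from compound 1 to compound 2 (beyond the scatter), so bromo in place of hydrogen on an aromatic carbon cost a modest amount of inhibition.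

Compound 3 `Fc1ccccc1-c1cn2ccnc2c(-c2ccc3ncn(C4CCCCC4)c3c2)n1` changes that same ring once more: 2-fluorophenyl in place of 4-bromophenyl on an aromatic carbon. For the measured compounds named here, no measured pair shows a 2-fluorophenyl, so the one step available only says that adding a halogen to the plain phenyl lowered the number. Since the halogen stays but moves and shrinks, compound 3 is expected to land near compound 2, with a number 5 percentage points higher from compound 2 to compound 3 (within the scatter) not expected to exceed the scatter. The estimate for compound 3 in this assay is 64%, between 48% and 78%.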

Compound 3, a percentage reported as inhibition, at one concentration (the size of the read-out at that concentration, not a potency): 22.8%
Estimate against measurement, compound 3: 41.2 percentage points above; measured number outside the range, below it.
By their numbers in this assay, from the lowest: compound 3; then compound 2; then compound 1.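

The step of a number 36.2 percentage points lower from compound 2 to compound 3 (beyond the scatter) shows that in this assay the kind and place of the halogen on this phenyl ring matter far more than the first pair could reveal. Against the plain phenyl, the 2-fluorophenyl gives a number 47.8 percentage points lower from compound 1 to compound 3 (beyond the scatter) and so brings a much larger drop than the bromo did. No measurement shown here explains why this small change on the ring has such a large effect.

The halogen and its place change together between compound 2 and compound 3, so the two cannot be separated; a 4-fluorophenyl or a 2-bromophenyl would pull them apart. As far as these compounds go, it also remains open how this position would respond to a group other than a halogen, such as a methoxy group, an amine or a carboxylic acid.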